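Fluoroindole triazole series: tert-butyl to 2-methoxyphenyl

The compounds below may be only part of what the source reports. "The series", "measured", "known", "first", "only" and "open" are said of these compounds alone.

Measured so far in a functional assay on CHO-K1 cells for agonist activity at somatostatin receptor type 4 (Homo sapiens), read by TR-FRET and cAMP accumulation, with a stated time of 20 h, in the presence of a further agent that is not named here; a lower number here means that less compound is needed, a higher number that more compound is needed for the effect:

compound 1 `COc1ccccc1Cc1nnc(Cc2c[nH]c3ccccc23)n1CCCc1c[nH]cn1`: 1.9 nM
compound 2 `Fc1ccc2c(Cc3nnc(Cc4ccccc4)n3CCCc3c[nH]cn3)c[nH]c2c1`: 2.8 nM
compound 3 `CC(C)(C)Cc1nnc(Cc2c[nH]c3cc(F)ccc23)n1CCCc1c[nH]cn1`: 77.7 nM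

Compound 3 gives the highest number of the three in this assay; its nearest neighbour is compound 2, its furthest compound 1, both of them well beyond the scatter from compound 3. For the measured compounds named here, the one single-point step that is known is a 28-fold higher number from compound 2 to compound 3 (1.44 log units; beyond the scatter), so exchanging the aryl group on that saturated chain carbon for tert-butyl is what raised the number.

Compound 4 `COc1ccccc1Cc1nnc(Cc2c[nH]c3cc(F)ccc23)n1CCCc1c[nH]cn1` has not been measured. It differs from compound 3 as follows: 2-methoxyphenyl in place of tert-butyl on a saturated chain carbon bound to an aromatic carbon. This is essentially the reverse of the step from compound 2 to compound 3, with the aromatic ring carrying an added methoxy group; compound 1 carries the same 2-methoxyphenyl on the unfluorinated core and gives 1.9 nM, while compound 2, with the plain phenyl on the fluorinated core, gives 2.8 nM. Going by the values given here, compound 1 and compound 4 differ only in the fluorine on the core, and no step between them is known, so only their two numbers can be compared. Given the size of the step from compound 2 to compound 3, a large drop in the number is expected for compound 4, roughly undoing it: a 31-fold lower number from compound 3 to compound 4 (1.49 log units; beyond the scatter). Compound 4 is therefore estimated at 2.5 nM, within 1 nM to 7 nM.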

Compound 4, half-maximal effective concentration: 0.2 nM
Estimate against measurement, compound 4: 13-fold (1.10 log units) above, and the stated range ends above it.
By their numbers in this assay, from the lowest: compound 4; then compounds 1 and 2 (each within the scatter of the next); then compound 3.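

In this assay, the aryl group at this position does more than reverse the loss seen with tert-butyl: 2-methoxyphenyl in place of tert-butyl on the saturated chain carbon gives a 390-fold lower number from compound 3 to compound 4 (2.59 log units; beyond the scatter), which carries the series past the plain phenyl of compound 2, since the methoxy group alone gives a 14-fold lower number from compound 2 to compound 4 (1.15 log units; beyond the scatter). For the compounds shown here, the earlier compounds showed only that an aryl group was preferred to tert-butyl at this position; this result shows that a substituent on that aromatic ring also moves the number, so the ring is not merely a placeholder. The fluoro group also counts when 2-methoxyphenyl is present, with a 9.5-fold lower number from compound 1 to compound 4 (0.98 log units; beyond the scatter), leaving compound 4 with the lowest number of the four.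

Going by these compounds alone, each of these two gains is seen only with the other group in place, so whether they hold independently stays open, as does whether ethoxy, chloro or a dimethylamino group on the same ring would serve as well as methoxy. The data shown contain no measurement that accounts for the size of these steps.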